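Ethyl for Methoxy in a Series Stuck at the Limit

The source may report more compounds than this note shows. Statements on the series, on what has been measured and on what is new or still open speak of the compounds shown alone.

Three sulfonamides share one core and differ only in the ring on the sulfonyl sulfur. Compound 1 `COc1cccc(S(=O)(=O)Nc2ccc3oc(-c4ccccc4)nc3c2)c1` carries a 3-methoxyphenyl, compound 2 `O=S(=O)(Nc1ccc2oc(-c3ccccc3)nc2c1)c1ccccc1Cl` a 2-chlorophenyl, and compound 3 `COc1ccc(S(=O)(=O)Nc2ccc3oc(-c4ccccc4)nc3c2)cc1` a 4-methoxyphenyl. In an assay on isolated protein for inhibition of malate dehydrogenase, mitochondrial (Sus scrofa), with stated times of 45 min and 30 min (on this read-out lower numbers stand for stronger inhibition and higher numbers for weaker inhibition), compound 1 gives only the limit > 63000 nM. Compound 2 likewise reaches only the limit > 63000 nM. Compound 3 also stops at the limit > 63000 nM. The steps a step that the two limits leave unreadable from compound 1 to compound 3 and a step that the two limits leave unreadable from compound 2 to compound 3 therefore cannot be sized, a point fixed by the limit of > 63000 nM in this assay, at which 3 of the 3 values shown sit. Compound 4 `CCc1ccc(S(=O)(=O)Nc2ccc3oc(-c4ccccc4)nc3c2)cc1` keeps everything else and swaps (ethyl in place of methoxy on an aromatic carbon). With every measured neighbour resting at the limit, compound 4 is expected to rest there too, which means an expected step that the limit leaves unreadable from compound 3 to compound 4. The estimate for compound 4 is 100000 nM, between 30000 nM and 400000 nM.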

Compound 4, half-maximal inhibitory concentration: > 63000 nM
Compound 4: no number, only a limit (the forecaster's own chance of this, stated with the estimate: 85%); the middle value lies beyond the limit too.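

Within the data shown here, compound 4 gives only a limit, as do compound 1, compound 2 and compound 3, and no step among them can be read. Going by these compounds, how strongly any of these four compounds inhibits the enzyme remains open.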